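Aryl swaps on a shared core: three measured, one pending

The source may hold more compounds than are shown below. What is called first, only, known or untested is meant among the compounds shown, and "the series" means these compounds.

Measured compounds
compound 1 `O=Cc1ccc(-c2cn3ccnc3c(-c3ccc4ncn(C5CCCCC5)c4c3)n2)cc1`: 3.69%
compound 2 `Fc1ccc(-c2cn3ccnc3c(-c3ccc4ncn(C5CCCCC5)c4c3)n2)cc1`: 3.49%
compound 3 `Fc1ccccc1-c1cn2ccnc2c(-c2ccc3ncn(C4CCCCC4)c3c2)n1`: 2.45%

In a functional assay on KM12 cells (Homo sapiens) for inhibition, read by sulforhodamine B assay, with a stated time of 48 h, tested at 10 uM (a lower number here means less inhibition, a higher number more inhibition at the concentration tested (going by the name of the read-out)), all three numbers are small and sit within the scatter of one another: a number 0.2 percentage points lower from compound 1 to compound 2 (within the scatter), a number 1.2 percentage points lower from compound 1 to compound 3 (within the scatter), a number 1 percentage points lower from compound 2 to compound 3 (within the scatter). Compound 3 therefore stands level with compound 1 and compound 2 on the numbers shown.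

Compound 4 `c1csc(-c2cn3ccnc3c(-c3ccc4ncn(C5CCCCC5)c4c3)n2)c1` differs from compound 3 in one place: thiophen-2-yl in place of 2-fluorophenyl on an aromatic carbon. For the measured compounds named here, the steps that bear on it are the earlier swaps of the aryl group on the same carbon, from compound 1 to compound 2 and from compound 2 to compound 3, both within the scatter. No step beyond the scatter is expected for compound 4 in this assay, a number 0.6 percentage points higher from compound 3 to compound 4 (within the scatter). Compound 4 is estimated at 3%, between -3% and 10%.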

Compound 4, a percentage reported as inhibition, at one concentration (the size of the read-out at that concentration, not a potency): 4.89%
For compound 4 the middle estimate is 1.9 percentage points below the measured one, within the range that was stated.
By their numbers in this assay, from the lowest: compounds 3, 2, 1 and 4 (each within the scatter of the next).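

In this assay the swap to thiophen-2-yl on this aromatic carbon stays within the scatter of all three earlier aryl groups (a number 2.4 percentage points higher from compound 3 to compound 4 (within the scatter) and a number 1.4 percentage points higher from compound 2 to compound 4 (within the scatter) and a number 1.2 percentage points higher from compound 1 to compound 4 (within the scatter)). The position has so far given level readings with a five-membered aromatic ring holding sulfur as well as with substituted six-membered carbon rings. No measurement on hand offers an explanation for these level readings. Open, as far as these compounds go, is whether an amine or a carboxylic acid on the aryl ring, or a longer chain in its place, would give a step beyond the scatter.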